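From compound 1 to compound 3 in a small series

The source may hold more compounds than are shown below. What is called first, only, known or untested is meant among the compounds shown, and "the series" means these compounds.

Among the measured compounds shown here, in a functional assay on THP-1 cells (Homo sapiens) for cytotoxicity, read by MTT assay, with a stated time of 24 h (a higher number here means a weaker inhibitor, a lower number a stronger inhibitor), compound 1 (`COc1cc(/C=C2\CN(C)C/C(=C\c3ccccc3F)C2=O)cc(OC)c1`) gives 1170 nM and compound 2 (`CN1C/C(=C\c2ccc(C(C)(C)C)cc2)C(=O)/C(=C/c2ccccc2F)C1`) gives 13400 nM as the only other number so far. Compound 1 therefore holds the lower of the two numbers, and the gap between them lies beyond the usual scatter of repeated measurements.

Compound 3 (`COc1cc(/C=C2\CN(C)C/C(=C\c3cccc([N+](=O)[O-])c3)C2=O)cc(OC)c1`) has no number yet. It departs from compound 1 in one place, where 3-nitrophenyl stands in place of 2-fluorophenyl on a double-bonded chain carbon bound to a double-bonded ring carbon (3-nitrophenyl in place of 2-fluorophenyl on a double-bonded chain carbon bound to a double-bonded ring carbon). For the measured compounds named here, no measured pair shows a change at this place, so the expectation starts from compound 1 at 1170 nM alone. The expected change in this assay is a 1.3-fold higher number from compound 1 to compound 3 (0.11 log units; within the scatter) and so none beyond the scatter, with only a slight lean towards a higher number. The range stays wide because compound 2 at 13400 nM sits far from compound 1 in the same measurement. The value estimated for compound 3 is 1500 nM (expected range 400 nM to 6000 nM).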

Compound 3, half-maximal inhibitory concentration: 1770 nM
Beside the measured number, compound 3's estimate is 1.2-fold (0.07 log units) below it; the range from low to high includes it.
By their numbers in this assay, from the lowest: compounds 1 and 3 (each within the scatter of the next); then compound 2.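

Notes on the place on a double-bonded chain carbon bound to a double-bonded ring carbon: in this assay the replacement of 2-fluorophenyl by 3-nitrophenyl gives a 1.5-fold higher number from compound 1 to compound 3 (0.18 log units; within the scatter) and provides the first reading of any change at this place. On the core of compound 1, this place therefore takes a group with more heavy atoms, with hydrogen-bond acceptors that 2-fluorophenyl lacks and without fluorine, and the shift stays within the scatter. No available measurement accounts for this outcome.

This single pair cannot separate the removal of the fluorine from the arrival of the nitro group, nor show whether the same replacement would hold on the core of compound 2. It also leaves open how this place responds to a phenyl ring carrying an amine or a carboxylic acid, or to a longer chain in place of the aromatic ring.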